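The source may hold more compounds than are shown below. What is called first, only, known or untested is meant among the compounds shown, and "the series" means these compounds.

Working notes on the series. The shared core carries a substituted anilide; compound 1 `Cc1cc(C)cc(NC(=O)CN2CCC(c3cccc[n+]3[O-])CC2)c1` gives 52 nM in a functional assay on HEK293 cells for agonist activity at D(4) dopamine receptor (Homo sapiens), read by FLIPR (on this read-out lower numbers stand for an effect already at smaller amounts and higher numbers for an effect only at larger amounts of compound), and compound 2 `O=C(CN1CCC(c2cccc[n+]2[O-])CC1)Nc1ccc(F)cc1` gives 85 nM. Going by the values given here, the only single-point step among the measured pairs, a 1.6-fold higher number from compound 1 to compound 2 (0.21 log units; within the scatter), is small. Compound 3 `O=C(CN1CCC(c2cccc[n+]2[O-])CC1)Nc1cccc(-c2ccccc2)c1` gives 360 nM, the highest number of the three, and its gaps to compound 1 and to compound 2 both lie beyond the scatter.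

The next compound, compound 4 `CSc1cccc(NC(=O)CN2CCC(c3cccc[n+]3[O-])CC2)c1`, is reached from compound 3 by methylsulfanyl in place of phenyl on an aromatic carbon. Among the compounds with values here, no measured step covers this change: the one measured step exchanges the whole anilide ring and stays within the scatter, so it does not bear on it directly. What the numbers do show is that compound 3, which carries the phenyl, sits beyond the scatter above the smaller anilides compound 1 and compound 2. On that basis compound 4 is expected to move back towards them, with a 3.3-fold lower number from compound 3 to compound 4 (0.51 log units; beyond the scatter) estimated as a lower number. The estimate for compound 4 is 110 nM, with a range from 40 nM to 300 nM.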

Compound 4, half-maximal effective concentration: 100 nM
Compound 4: the middle estimate sits 1.1-fold (0.04 log units) above what was measured, and the stated range covers the measured number.
By their numbers in this assay, from the lowest: compounds 1, 2 and 4 (each within the scatter of the next); then compound 3.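

In this assay, going by these compounds alone, the exchange on this aromatic carbon gives a 3.6-fold lower number from compound 3 to compound 4 (0.56 log units; beyond the scatter), the first measured step confined to one substituent on the anilide ring. It also places the compound with the methylsulfanyl among the other anilides: a 1.2-fold higher number from compound 2 to compound 4 (0.07 log units; within the scatter) and a 1.9-fold higher number from compound 1 to compound 4 (0.28 log units; within the scatter) both stay within the scatter, leaving compound 3, with its phenyl, as the only one of the four set apart. No measurement at hand accounts for this step.

Phenyl and methylsulfanyl are the only two groups compared on this aromatic carbon, so the series does not yet tell whether the higher number of compound 3 is particular to phenyl. An amine, a carboxylic acid or a longer chain at the same place would test how far this holds.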